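Replacing the phenyl with methyl at the two-nitrogen ring carbon

A few compounds are considered here, and "the series" means these few. Any claim that something is new, unique, unknown or untested is made for them only; others in the source may bear on it.

Of the compounds shown here, two of the shared core have been measured. Compound 1 `Cc1cc2nc(N)nc(N)c2c(=O)[nH]1` gives 6% in an assay on isolated protein for inhibition of ribosomal protein S6 kinase alpha-5 (Homo sapiens), read by mobility shift assay, tested at 30 uM; on this read-out higher numbers stand for more inhibition at the one concentration tested (going by the name of the read-out) and lower numbers for less inhibition. Compound 2 `Cc1cc2nc(-c3ccccc3)nc(N)c2c(=O)[nH]1`, with phenyl in place of amino on an aromatic carbon, gives 15% in this assay. The step of a number 9 percentage points higher from compound 1 to compound 2 (within the scatter) does not separate the two; compound 2 and compound 1 stand within the scatter of each other, so their numbers count as level.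

Compound 3 `Cc1nc(N)c2c(=O)[nH]c(C)cc2n1` is not yet measured. It differs from compound 2 by methyl in place of phenyl on an aromatic carbon. Among the measured compounds shown here, no measured step concerns methyl at this carbon; the only step available, a number 9 percentage points higher from compound 1 to compound 2 (within the scatter), shows that exchanging the group at this position moved the number within the scatter. On that basis a step of no size beyond the scatter is expected, a number 6 percentage points lower from compound 2 to compound 3 (within the scatter), if anything slightly downward. Compound 3 is therefore estimated to give 9% in this assay, between -5% and 22%.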

Compound 3, a percentage reported as inhibition, at one concentration (the size of the read-out at that concentration, not a potency): 0%
Compound 3: middle estimate off by 9 percentage points, on the high side; measured number inside the range.
By their numbers in this assay, from the lowest: compounds 3, 1 and 2 (each within the scatter of the next, the first and the last beyond it).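

At the aromatic carbon between two ring nitrogen atoms, this assay now shows a modest step beyond the scatter, a number 15 percentage points lower from compound 2 to compound 3 (beyond the scatter), with methyl in place of phenyl. Methyl in place of amino does not separate the compounds, at a number 6 percentage points lower from compound 1 to compound 3 (within the scatter), so only the pair of phenyl and methyl is resolved at this carbon, and the ring-bearing compound 2 still gives just 15% at the one concentration tested. The data offer no explanation for the difference between phenyl and methyl.

Going by these compounds, whether the phenyl ring itself matters or any larger group would serve equally remains open, and a cyclohexyl ring or a longer alkyl chain at this carbon would help to distinguish these possibilities. A pyridine ring or a substituted phenyl, such as methoxyphenyl, would show whether the number can rise any further at this position.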